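The source may report more compounds than this note shows. Statements on the series, on what has been measured and on what is new or still open speak of the compounds shown alone.

Three compounds share one core and were tested in a functional assay on MKN-45 cells (Homo sapiens) for antiproliferative activity, tested at 1 uM; a lower number here means less inhibition, a higher number more inhibition at the concentration tested (going by the name of the read-out). Compound 1 `CCOC(=O)c1ccc(CO/N=C/c2c(C)nn(C)c2Oc2ccc(Cl)cc2)cc1` gives 20.9%. Compound 2 `Cc1nn(C)c(Oc2ccc(Cl)cc2)c1/C=N/OCc1ccc([N+](=O)[O-])cc1` gives 24.6%, the highest of the three numbers, though its gap to compound 1 falls within the usual scatter. Compound 3 `CCOC(=O)c1ccc(CO/N=C/c2c(C)nn(-c3ccccc3)c2Oc2ccc(Cl)cc2)cc1` gives -17.8%, the lowest of the set. Two single-point changes are on record: the exchange of ethoxycarbonyl for nitro on the aromatic carbon gave a number 3.7 percentage points higher from compound 1 to compound 2 (within the scatter), while the exchange of methyl for phenyl on the aromatic nitrogen gave a number 38.7 percentage points lower from compound 1 to compound 3 (beyond the scatter), a large drop.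

The step now followed leads from compound 2 to compound 4 `Cc1nn(C)c(Oc2ccccc2)c1/C=N/OCc1ccc([N+](=O)[O-])cc1`. The change is hydrogen in place of chloro on an aromatic carbon. Among the measured compounds shown here, neither measured step touches this chlorophenoxy part of the molecule, so nothing directly comparable is available; the only small change on record, at a distant aromatic carbon, stayed within the scatter. On that basis a step of a number 6.6 percentage points lower from compound 2 to compound 4 (within the scatter) is expected, that is, none beyond the scatter. For compound 4 the estimated value in this assay is 18%, with a range from -4% to 38%.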

Compound 4, a percentage reported as inhibition, at one concentration (the size of the read-out at that concentration, not a potency): 18.3%
Beside the measured number, compound 4's estimate is 0.3 percentage points below it; low and high end bracket the measured number.
By their numbers in this assay, from the lowest: compound 3; then compounds 4, 1 and 2 (each within the scatter of the next).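

Putting hydrogen in place of chloro on the phenoxy ring gives, in this assay, a number 6.3 percentage points lower from compound 2 to compound 4 (within the scatter). Among the compounds shown here, this is the first look at the 4-chlorophenoxy part of the molecule, and it shows that the read-out at this single concentration does not separate 4-chlorophenoxy from plain phenoxy, so the chloro group is not required to keep the number at this level. No measurement is available that would explain this step or say what the chloro group does in these compounds.

Chloro and hydrogen are the only two substituents shown at this position, so it remains open whether a methoxy group, an amine or a carboxylic acid there would move the number beyond the scatter. Going by these compounds, it also remains open whether the same exchange would give a similar step with ethoxycarbonyl in place of nitro, or with phenyl in place of methyl on the aromatic nitrogen.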